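Swapping the 4-hydroxyphenyl group of compound 2

The source may hold more compounds than are shown below. What is called first, only, known or untested is meant among the compounds shown, and "the series" means these compounds.

In a functional assay on DU-145 cells (Homo sapiens) for inhibition, read by trypan blue exclusion, with a stated time of 96 h (on this read-out higher numbers stand for weaker inhibition of growth and lower numbers for stronger inhibition of growth), compound 1 `COc1ccccc1/C=C(\C(=O)c1ccc(Cl)cc1)S(=O)(=O)Cc1ccc(Cl)c(Cl)c1` gives 1000 nM, and compound 2 `O=C(/C(=C\c1ccc(O)cc1)S(=O)(=O)Cc1ccc(Cl)c(Cl)c1)c1ccc(Cl)cc1` gives 10000 nM, the higher of the two numbers. Compound 3 `O=C(/C(=C\c1ccc(F)cc1C(F)(F)F)S(=O)(=O)Cc1ccc(Cl)c(Cl)c1)c1ccc(Cl)cc1` has 4-fluoro-2-(trifluoromethyl)phenyl in place of 4-hydroxyphenyl (4-fluoro-2-(trifluoromethyl)phenyl in place of 4-hydroxyphenyl on a double-bonded chain carbon bound to a double-bonded chain carbon). For the measured compounds named here, the only measured step that bears on this is a 10-fold higher number from compound 1 to compound 2 (1.00 log units; beyond the scatter), beyond the scatter, which brought in that same 4-hydroxyphenyl in place of 2-methoxyphenyl. Going by these compounds, the entering group itself is untested, so this is thin evidence. Removing 4-hydroxyphenyl is expected to give a 6.7-fold lower number from compound 2 to compound 3 (0.82 log units; beyond the scatter), towards stronger inhibition of growth. Compound 3 is estimated at 1500 nM, within a range of 300 nM to 6000 nM.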

Compound 3, concentration for 50% growth inhibition: 1000 nM
Beside the measured number, compound 3's estimate is 1.5-fold (0.18 log units) above it; low and high end bracket the measured number.
By their numbers in this assay, from the lowest: compounds 1 and 3 (each within the scatter of the next); then compound 2.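

In this assay, putting 4-fluoro-2-(trifluoromethyl)phenyl on this double-bonded chain carbon gives a 10-fold lower number from compound 2 to compound 3 (1.00 log units; beyond the scatter), so the weak result of compound 2 does not extend to every substituted phenyl group here. Set against 2-methoxyphenyl, the same group gives no change at the digits printed from compound 1 to compound 3 (within the scatter), so among these three compounds only 4-hydroxyphenyl stands apart. Nothing available explains this difference. Still open, going by these compounds, is how plain phenyl, 4-methoxyphenyl or 4-aminophenyl would compare at this carbon, which would help show whether the hydroxyl group itself sets compound 2 apart.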